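The compounds below may be only part of what the source reports. "The series", "measured", "known", "first", "only" and "open" are said of these compounds alone.

Compound 1, whose structure is `Cc1cc(C(=O)O)ccc1OCCCCOc1ccc(C(=O)CC(C)C)c(O)c1C`, opens the set. In an ADME assay on a cell-free system (plasma, Rattus norvegicus) for metabolic stability, read by LC-MS, with a stated time of 60 min, tested at 100 uM (on this read-out higher numbers stand for a more stable compound and lower numbers for a less stable compound), compound 1 gives 100%. Compound 2, with the structure `Cc1cc(OCCCCOc2ccc(C(=O)CC(C)C)c(O)c2C)ccc1C(=O)O`, differs from compound 1 by 4-carboxy-3-methylphenyl in place of 4-carboxy-2-methylphenyl on an oxygen on a saturated carbon, and in this assay compound 2 gives 101%, so the change produced a number 1 percentage points higher from compound 1 to compound 2 (within the scatter). Compound 3, with the structure `Cc1cc(C(=O)O)ccc1OCCCCOc1ccc(C(=O)CC2CCCC2)c(O)c1C`, carries a different core than compound 1: the two cores differ by cyclopentyl in place of isopropyl on a saturated chain carbon bound to a carbonyl carbon. In this assay compound 3 gives 99%, and against compound 1 that reads as a number 1 percentage points lower from compound 1 to compound 3 (within the scatter). All three numbers therefore sit close together.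

Compound 4, whose structure is `Cc1cc(OCCCCOc2ccc(C(=O)CC3CCCC3)c(O)c2C)ccc1C(=O)O`, has not been measured in this assay. It differs from compound 3 by 4-carboxy-3-methylphenyl in place of 4-carboxy-2-methylphenyl on an oxygen on a saturated carbon, and since the surroundings of the place are described in the same words as for the change from compound 1 to compound 2, this is the same change on the core of compound 3. For compound 4 the expected step is a number 1 percentage points higher from compound 3 to compound 4 (within the scatter), which is estimated to sit beside the earlier step because a number 1 percentage points higher from compound 1 to compound 2 (within the scatter) is what the same change gave on the core of compound 1. The estimate for compound 4 in this assay is therefore 100%, expected to fall between 90% and 108%, though it rests on a single earlier pair and on three compounds in all.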

Compound 4, percent of the compound remaining: 114%
Compound 4: the middle estimate sits 14 percentage points below what was measured, outside the stated range (above it).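

On the core of compound 3, 4-carboxy-3-methylphenyl in place of 4-carboxy-2-methylphenyl gave a number 15 percentage points higher from compound 3 to compound 4 (beyond the scatter) in this assay, and on the core of compound 2, cyclopentyl in place of isopropyl gave a number 13 percentage points higher from compound 2 to compound 4 (beyond the scatter), so each change now has a reading on two cores. The exchange of the two carboxy-methylphenyl groups cannot be said to behave differently from one core to the other, even though only its second step stands beyond the scatter: the same change on two cores in this assay, a number 1 percentage points higher (within the scatter) from compound 1 to compound 2 and a number 15 percentage points higher (beyond the scatter) from compound 3 to compound 4, 14 percentage points apart, within the scatter of two such steps. Among these compounds, the same holds for cyclopentyl in place of isopropyl, but with only two readings per change, this shows no measurable difference rather than proving that either change carries over at a fixed size, and it gives no reason for the higher number of compound 4: the same change on two cores in this assay, a number 1 percentage points lower (within the scatter) from compound 1 to compound 3 and a number 13 percentage points higher (beyond the scatter) from compound 2 to compound 4, 14 percentage points apart, within the scatter of two such steps.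

The compounds shown leave open whether the result would hold with a longer chain in place of the one linking the two rings, or with an ester or an amide in place of the carboxylic acid. They also leave open how a cyclohexyl or a phenyl group would compare with isopropyl and cyclopentyl on the saturated chain carbon bound to a carbonyl carbon.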